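Resolving the stereocentre of compound 1

A few compounds are considered here, and "the series" means these few. Any claim that something is new, unique, unknown or untested is made for them only; others in the source may bear on it.

Among the three compounds measured in a functional assay for antagonist activity at Oxoeicosanoid receptor 1 (Homo sapiens), read by fluorescence and calcium flux, with stated times of 2 min and 1 min (on this read-out higher numbers stand for weaker inhibition and lower numbers for stronger inhibition), compound 1 `CC(CC(=O)O)CC(=O)c1c(CCCCCCc2ccccc2)n(C)c2ccc(Cl)cc12` gives 0.28 nM, the lowest number of the set; compound 3 `CC(CC(=O)O)CC(=O)c1c(CCCCCC(F)(F)F)n(C)c2ccc(Cl)cc12` gives 38 nM, and compound 2 `CC(CC(=O)O)CC(=O)c1c(CCCc2ccccc2)n(C)c2ccc(Cl)cc12` gives 223 nM. Compound 4 `C[C@H](CC(=O)O)CC(=O)c1c(CCCCCCc2ccccc2)n(C)c2ccc(Cl)cc12` differs from compound 1 in this way: the two compounds have the same atoms and bonds; at least one stereo element is drawn with a configuration in one of them and without one in the other: 1 of 1 stereo elements differ; a stereocentre at a saturated chain carbon is drawn without a configuration in compound 1 and S in compound 4. Among the compounds with values here, none of the measured steps, an 800-fold higher number from compound 1 to compound 2 (2.90 log units; beyond the scatter), a 140-fold higher number from compound 1 to compound 3 (2.13 log units; beyond the scatter) or a 5.9-fold lower number from compound 2 to compound 3 (0.77 log units; beyond the scatter), concerns a stereocentre; they all change the chain, so none bears directly on this step. A single configured form may match or fall within the scatter of compound 1, or give a larger number if it is the less active form. Compound 4 is therefore expected at about 0.3 nM, in a range of 0.1 nM to 3 nM, a step of a 1.1-fold higher number from compound 1 to compound 4 (0.03 log units; within the scatter).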

Compound 4, half-maximal inhibitory concentration: 0.12 nM
Compound 4: the middle estimate sits 2.5-fold (0.40 log units) above what was measured, and the stated range covers the measured number.
By their numbers in this assay, from the lowest: compound 4; then compound 1; then compound 3; then compound 2.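

In this assay, drawing the saturated chain carbon as S gives a 2.3-fold lower number from compound 1 to compound 4 (0.37 log units; beyond the scatter), a modest step but one beyond the scatter, and the first here that leaves the chain untouched. It is much smaller than chain changes such as an 800-fold higher number from compound 1 to compound 2 (2.90 log units; beyond the scatter), yet it shows that configuration at this stereocentre also moves the number, with the S form reading lower than the undefined form. The step rests on a single structural difference: the fact that one of compounds 1 and 4 is drawn with a defined configuration and the other without, at the place where they differ

The compounds shown leave open how the R form reads in this assay. They also leave open whether an ethyl group in place of the methyl on this stereocentre would keep so low a number.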